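The source may report more compounds than this note shows. Statements on the series, on what has been measured and on what is new or still open speak of the compounds shown alone.

The measured compounds:
Compound 1, `Cc1cc(NC(=O)Cn2nnc(-c3ccccc3)n2)n(C2CCOCC2)n1`, gives 115% in an assay on HEK293 cells for activation of Kir3.1/Kir3.2 (Homo sapiens), read by thallium flux; on this read-out lower numbers stand for smaller maximal responses and higher numbers for larger maximal responses.
Compound 2, `CCC(C)n1nc(C)cc1NC(=O)Cn1nnc(-c2ccccc2)n1`, gives > 69% in this assay; that value is a limit of the assay, not a number.
Compound 3, `Cc1cc(NC(=O)Cn2nnc(-c3ccccc3)n2)n(C2CCS(=O)(=O)C2)n1`, gives 93% in this assay.

Compound 3 stands lowest of the two numbers, with compound 1 as its nearest neighbour. The step of a number 22 percentage points lower from compound 1 to compound 3 (beyond the scatter) is the only one that can be read in size; the steps a step that the limit leaves unreadable from compound 1 to compound 2 and a step that the limit leaves unreadable from compound 2 to compound 3 cannot, since one value sits at a limit (the limit of > 69% in this assay, at which 1 of the 3 values shown sits). Compound 4, `Cc1cc(NC(=O)Cn2nnc(-c3ccccc3)n2)n(C2CCS(=O)(=O)CC2)n1`, differs from compound 3 in one place: 1,1-dioxothian-4-yl in place of 1,1-dioxothiolan-3-yl on an aromatic nitrogen. The group entering is a six-membered ring, as is the oxan-4-yl group of compound 1 on the same aromatic nitrogen. Among the compounds with values here, the one readable step, a number 22 percentage points lower from compound 1 to compound 3 (beyond the scatter), was a modest lowering. For compound 4 a step of a number 7 percentage points higher from compound 3 to compound 4 (within the scatter) is expected, within the scatter or slightly upward. Compound 4 is therefore estimated at 100%, between 80% and 120%.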

Compound 4, largest response reached (Emax), in percent of the reference or control that the assay uses: > 25%
Compound 4 gave a limit, no number; the forecaster's own chance of this, stated with the estimate: 5%; the middle value is on the limit's open side.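

In this assay compound 4 gives > 25%, which is a limit and not a number, so its steps from compound 1, compound 2 and compound 3 cannot be read. The compounds shown leave open how the 1,1-dioxothian-4-yl group of compound 4 compares with the 1,1-dioxothiolan-3-yl group of compound 3.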